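Sulfonamide chain variation on the shared core: hydroxy for methyl

The source may report more compounds than this note shows. Statements on the series, on what has been measured and on what is new or still open speak of the compounds shown alone.

Three compounds of the series have numbers in a functional assay on K562 cells (Homo sapiens) for antiproliferative activity, read by CCK-8 assay, with a stated time of 72 h; on this read-out lower numbers stand for stronger inhibition of growth and higher numbers for weaker inhibition of growth. Compound 1 `CCCNS(=O)(=O)c1ccc(Nc2ncc3c(n2)N(C2CCCC2)[C@H](CC)C(=O)N3C)cc1` gives 548 nM, the lowest of the three. For the measured compounds named here, compound 2 `CC[C@@H]1C(=O)N(C)c2cnc(-n3ccc4cc(F)ccc43)nc2N1C1CCCC1` gives 21200 nM in this assay, and compound 3 `CCC1C(=O)N(C)c2cnc(-n3ccc4cc(C(N)=O)ccc43)nc2N1c1ccn(C)n1` gives 31300 nM in this assay; both gaps to compound 1 lie beyond the scatter, so compound 1 is the most active compound measured so far. Compounds 2 and 3 differ from compound 1 in more than one place, so their numbers show only that they sit far above it and nothing more.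

Compound 4 `CC[C@@H]1C(=O)N(C)c2cnc(Nc3ccc(S(=O)(=O)NCCO)cc3)nc2N1C1CCCC1` has not yet been measured in this assay. It differs from compound 1 as follows: hydroxy in place of methyl on a saturated chain carbon, two bonds along the chain from a sulfonamide nitrogen. Going by the values given here, the change sits at the far end of the chain on the sulfonamide nitrogen, away from the shared core, and no measured pair isolates it. The expectation is therefore a step from compound 1 to compound 4 of a 1.1-fold higher number from compound 1 to compound 4 (0.04 log units; within the scatter) in this assay, that is, no change beyond the scatter in either direction. The number for compound 4 in this assay is estimated at 600 nM, with a range from 200 nM to 1800 nM.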

Compound 4, concentration for 50% growth inhibition: 546 nM
Compound 4: the middle estimate sits 1.1-fold (0.04 log units) above what was measured; low and high end bracket the measured number.
By their numbers in this assay, from the lowest: compounds 4 and 1 (each within the scatter of the next); then compounds 2 and 3 (each within the scatter of the next).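

Hydroxy in place of methyl on a saturated chain carbon, two bonds along the chain from a sulfonamide nitrogen, gives a 1.0-fold lower number from compound 1 to compound 4 (0.00 log units; within the scatter) in this assay, and this is the first pair in the series to isolate a single place. At this position, propyl and 2-hydroxyethyl are not told apart by the read-out, so the hydroxy, with the hydrogen-bond donor and acceptor counted for it, can stand on this chain of the shared core without a step beyond the scatter, a statement that rests on this one pair alone. Nothing at hand bears on why the two chains read alike.

The compounds shown leave open whether this flat result holds for other groups at the chain end, such as an amine or a carboxylic acid, or for a longer chain carrying the same hydroxy. They also leave open whether a hydroxy at this place reads the same on a different core, and compounds 2 and 3, which differ from compound 1 in more than one place, cannot settle that.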